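Compound 3 to compound 4: the ester chain

The compounds below may be only part of what the source reports. "The series", "measured", "known", "first", "only" and "open" are said of these compounds alone.

Measured values in an ADME assay on HeLa cells (Homo sapiens) for cytotoxicity (on this read-out lower numbers stand for higher toxicity in this test and higher numbers for lower toxicity in this test), are as follows.
- compound 1 `COC(=O)/C=C/CNC(=O)c1cccc2c1NCCC2` gives > 30000 nM
- compound 2 `COC(=O)/C=C/CNC(=O)c1cc(C)cc2c1NC(C)(C)C=C2C` gives > 30000 nM
- compound 3 `COC(=O)CCCNC(=O)c1cccc2c1NC(C)(C)C[C@H]2C` gives > 30000 nM

Compound 3 stands at > 30000 nM as a limit of the assay and not a number. The whole set stands the same way (the limit of > 30000 nM in this assay, at which 3 of the 3 values shown sit). Compound 4 `COC(=O)/C=C/CNC(=O)c1cccc2c1NC(C)(C)C[C@H]2C` differs from compound 3 by one change (2-(methoxycarbonyl)ethenyl in place of 2-(methoxycarbonyl)ethyl on a saturated chain carbon bound to an amide-type nitrogen). Compound 1 already carries 2-(methoxycarbonyl)ethenyl and gives > 30000 nM as a limit. Compound 2 also carries it and gives > 30000 nM as a limit. No step beyond the scatter is expected in this assay and the estimate means a step that the limit leaves unreadable from compound 3 to compound 4 as the expected step. For compound 4 the expected value is 35000 nM with an estimated range of 20000 nM to 60000 nM as the working figure.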

Compound 4, half-maximal cytotoxic concentration: > 30000 nM
Compound 4 gave a limit, no number; the forecaster's own chance of this, stated with the estimate: 85%; the middle value does not contradict the limit.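

In this assay compound 3 and compound 4 each give only a limit, so no step can be read between them: the limit of > 30000 nM in this assay, at which 4 of the 4 values shown sit.

The compounds shown leave open how 2-(methoxycarbonyl)ethenyl and 2-(methoxycarbonyl)ethyl compare on this read-out, and whether any change to the shared core gives a readable value in this assay.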